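This account rests on a few compounds, and the source may have more. Where it says the series, first, only, none or still open, it means among the compounds named here.

Working notes on the series, read in a functional assay on MCF7 cells (Homo sapiens) for inhibition; a lower number here means a stronger inhibitor, a higher number a weaker inhibitor. Compound 1 `CCCCCCCC[C@@]1(C)SC(=O)C=C1OC` gives only a limit, > 50 ug/mL. Compound 2 `C=CCOC1=CC(=O)S[C@]1(C)CCCCCCCC` also gives only a limit, > 50 ug/mL. Compound 3 `C=CCNC(=O)COC1=CC(=O)S[C@]1(C)CCCCCCCC` likewise stands at a limit, > 50 ug/mL, and has no number of its own. Among the measured compounds shown here, the whole series so far rests on (the limit of > 50 ug/mL in this assay, at which 3 of the 3 values shown sit).

Compound 4 `CCCCCCCC[C@@]1(C)SC(=O)C=C1OC(=O)CC` differs from compound 3 as follows: propanoyl in place of (allylcarbamoyl)methyl on an oxygen on an unsaturated carbon. The group on the oxygen on an unsaturated carbon is what changes.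

For the measured compounds named here, three measured steps bear on this: a step that the two limits leave unreadable from compound 1 to compound 2, a step that the two limits leave unreadable from compound 1 to compound 3 and a step that the two limits leave unreadable from compound 2 to compound 3. None has a readable size, so they support no direction and no step beyond the scatter in this assay. The expected step is a step that the limit leaves unreadable from compound 3 to compound 4. For compound 4 the estimated value is 60 ug/mL, with an expected range of 25 ug/mL to 120 ug/mL.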

Compound 4, half-maximal inhibitory concentration: 22.6 ug/mL
Beside the measured number, compound 4's estimate is 2.7-fold (0.42 log units) above it; the whole stated range lies above it.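

In this assay, among the compounds shown here, propanoyl on the oxygen on an unsaturated carbon gives the first readable direction at this place, where the earlier steps cannot be read: an at least 2.2-fold lower number from compound 3 to compound 4 (0.34 log units; beyond the scatter). The same holds against allyl, an at least 2.2-fold lower number from compound 2 to compound 4 (0.34 log units; beyond the scatter), and against methyl, an at least 2.2-fold lower number from compound 1 to compound 4 (0.34 log units; beyond the scatter). Each step is only a lower bound because its partner compound stands at a limit: the limit of > 50 ug/mL in this assay, at which 3 of the 4 values shown sit.

Going by these compounds, the full size of these steps stays open. So does whether an acetyl group or a longer hexanoyl chain on this oxygen would move the number further.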